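A Cyano Group Replaces Trifluoromethyl on a Shared Core

The compounds below may be only part of what the source reports. "The series", "measured", "known", "first", "only" and "open" are said of these compounds alone.

Compound 3, `Cc1ccc(C2=NN(c3nc(-c4ccc(C(F)(F)F)cc4)cs3)C(c3ccc(F)cc3)C2)s1`, was tested in a functional assay on A549 cells (Homo sapiens) for antiproliferative activity, read by XTT assay, with a stated time of 24 h; on this read-out higher numbers stand for weaker inhibition and lower numbers for stronger inhibition. In this assay compound 3 gives > 500 ug/mL, which is a limit of the assay rather than a measured number. Two relatives share its core and differ from it only on one aromatic carbon. Compound 1, `Cc1ccc(C2=NN(c3nc(-c4ccccc4)cs3)C(c3ccc(F)cc3)C2)s1`, carries hydrogen where compound 3 carries trifluoromethyl; in this assay compound 1 gives > 500 ug/mL, again a limit. Compound 2, `Cc1ccc(C2=NN(c3nc(-c4ccc(S(C)(=O)=O)cc4)cs3)C(c3ccc(F)cc3)C2)s1`, carries methylsulfonyl at that place; in this assay compound 2 gives > 500 ug/mL, also a limit. Because the limit of > 500 ug/mL in this assay, at which 3 of the 3 values shown sit, is where every value sits, none of the steps among these three can be sized: a step that the two limits leave unreadable from compound 1 to compound 2, a step that the two limits leave unreadable from compound 1 to compound 3 and a step that the two limits leave unreadable from compound 2 to compound 3 all stay unreadable.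

Compound 4, `Cc1ccc(C2=NN(c3nc(-c4ccc(C#N)cc4)cs3)C(c3ccc(F)cc3)C2)s1`, has not yet been measured. Its difference from compound 3 is cyano in place of trifluoromethyl on an aromatic carbon. All three measured steps bear on this change, but none of them carries a readable size, so no direction beyond the scatter can be drawn from them. Compound 4 is therefore expected to stay at the same limit, with an estimated value in this assay of 600 ug/mL and a range from 250 ug/mL to 3000 ug/mL. The expected step is a step that the limit leaves unreadable from compound 3 to compound 4.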

Compound 4, half-maximal inhibitory concentration: 322 ug/mL
For compound 4 the middle estimate is 1.9-fold (0.27 log units) above the measured one; the range from low to high includes it.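

In this assay compound 4 gives 322 ug/mL, the only actual number among the compounds shown on this shared core. This position can therefore carry a group that gives a readable value, and cyano is the one group shown that does so, though each comparison yields only a floor: an at least 1.5-fold lower number from compound 3 to compound 4 (0.19 log units; that floor lies within the scatter), an at least 1.5-fold lower number from compound 2 to compound 4 (0.19 log units; that floor lies within the scatter) and an at least 1.5-fold lower number from compound 1 to compound 4 (0.19 log units; that floor lies within the scatter). From the compounds shown here alone, each floor rests on a limit rather than on a second number, so the true sizes of these steps remain unknown and the steps among compound 1, compound 2 and compound 3 still cannot be read: the limit of > 500 ug/mL in this assay, at which 3 of the 4 values shown sit.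

It remains open whether cyano in place of trifluoromethyl truly changes the read-out by more than the scatter, and nothing shown explains why a cyano group should differ from the other groups at this place. Going by these compounds, it is also open what an amine, a carboxylic acid or a longer chain on this aromatic carbon would give, and whether any of them would yield a number rather than a limit.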